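Methoxy addition on a weakly antiproliferative series

The compounds below may be only part of what the source reports. "The series", "measured", "known", "first", "only" and "open" are said of these compounds alone.

Measured in a functional assay on HCT-116 cells (Homo sapiens) for antiproliferative activity, read by MTT assay, with a stated time of 72 h; a higher number here means a weaker inhibitor, a lower number a stronger inhibitor:
- compound 1 `COc1cc(OC)cc(-c2cccc(NC(=O)CCc3cccc4c3COB4O)c2)c1`: 50000 nM
- compound 2 `COc1cccc(-c2cccc(NC(=O)CCc3ccccc3)c2)c1`: 40000 nM

Only these two compounds have been measured so far, and the value of compound 2 lies within the scatter of the value of compound 1. Neither can be ranked over the other.

Compound 3 `COc1cc(OC)cc(-c2cccc(NC(=O)CCc3ccccc3)c2)c1` follows from compound 2 with methoxy in place of hydrogen on an aromatic carbon. The same methoxy pattern occurs in compound 1, which gives 50000 nM, but that compound also differs elsewhere, so the comparison is only loose. Going by the values given here, no measured step isolates this change.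

In this assay, no shift beyond the scatter is expected, and the expected step of a 1.1-fold higher number from compound 2 to compound 3 (0.05 log units; within the scatter) is small. For compound 3 the estimated value is 45000 nM, with an expected range of 20000 nM to 100000 nM.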

Compound 3, half-maximal inhibitory concentration: > 100000 nM
Compound 3: only a limit was reported; the forecaster's own chance of this, stated with the estimate: 25%; middle value at least 2.2-fold (0.34 log units) from the limit.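

In this assay, methoxy in place of hydrogen on this aromatic carbon, meta to a large group and meta to a methoxy group, gives an at least 2.5-fold higher number from compound 2 to compound 3 (0.39 log units; beyond the scatter), so this position is not indifferent to the change, which the loose match with compound 1 could not show. With both methoxy groups held in place, the group of 6 heavy atoms in place of the boron-bearing group of 10 heavy atoms gives an at least 2.0-fold higher number from compound 1 to compound 3 (0.30 log units; that floor lies within the scatter), a floor that does not yet separate the two compounds. Compound 3 has only a limit, so both steps are floors rather than sizes: the limit of > 100000 nM in this assay, at which 1 of the 3 values shown sits.

Going by these compounds, the true size of the methoxy step remains open. Also open, on these data alone, is whether a fluorine atom or a hydroxy group on the same carbon would give a step of the same kind.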